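An Ethoxy Exchange on the Weakest Compound

The source may report more compounds than this note shows. Statements on the series, on what has been measured and on what is new or still open speak of the compounds shown alone.

In a functional assay on HeLa cells (Homo sapiens) for antiproliferative activity, with a stated time of 48 h (a higher number here means a weaker inhibitor, a lower number a stronger inhibitor), compound 1 `C=C(Br)C(=O)Nc1ccc(/C=C/C(=O)c2ccc(I)cc2)cc1` gives 7700 nM and compound 2 `C=C(Br)C(=O)Nc1ccc(/C=C/C(=O)c2ccc(OCC)cc2)cc1` gives 750 nM as its value. Compound 3 `Nc1ccc(/C=C/C(=O)c2ccc(I)cc2)cc1` has the highest number of the three at 58000 nM and is the weakest inhibitor measured so far. Compound 1 is its nearest neighbour and compound 2 the furthest.

Compound 4 `CCOc1ccc(C(=O)/C=C/c2ccc(N)cc2)cc1` differs from compound 3 by ethoxy in place of iodo on an aromatic carbon. The same exchange has been measured once, with the (1-bromoethenyl)carbonyl group on the nitrogen, as a 10-fold lower number from compound 1 to compound 2 (1.01 log units; beyond the scatter) and this large step bears on it most directly. The modest step of a 7.5-fold higher number from compound 1 to compound 3 (0.88 log units; beyond the scatter) shows what losing that group does to the iodo compound. The exchange itself has not been measured without that group. A large step toward a lower number, beyond the scatter, is therefore expected and is estimated as an 8.3-fold lower number from compound 3 to compound 4 (0.92 log units; beyond the scatter) for this pair. Compound 4 is expected near 7000 nM in this assay with a range from 2000 nM to 25000 nM around that estimate.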

Compound 4, half-maximal inhibitory concentration: 41000 nM
The estimate for compound 4 lay 5.9-fold (0.77 log units) below the measured number; the measured number lies above the stated range.
By their numbers in this assay, from the lowest: compound 2; then compound 1; then compounds 4 and 3 (each within the scatter of the next).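

In this assay, with no (1-bromoethenyl)carbonyl group on the nitrogen, ethoxy in place of iodo gives only a 1.4-fold lower number from compound 3 to compound 4 (0.15 log units; within the scatter), so the gain seen with that group present does not carry over to this core: the same change on two cores in this assay, a 10-fold lower number (1.01 log units; beyond the scatter) from compound 1 to compound 2 and a 1.4-fold lower number (0.15 log units; within the scatter) from compound 3 to compound 4, 7.3-fold (0.86 log units) apart, beyond the scatter of two such steps

Read the other way, losing that group costs far more on the ethoxy compounds, with a 55-fold higher number from compound 2 to compound 4 (1.74 log units; beyond the scatter), than on the iodo compounds: the same change on two cores in this assay, a 7.5-fold higher number (0.88 log units; beyond the scatter) from compound 1 to compound 3 and a 55-fold higher number (1.74 log units; beyond the scatter) from compound 2 to compound 4, 7.3-fold (0.86 log units) apart, beyond the scatter of two such steps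

The two changes are therefore not independent in these four compounds, and the effect of the exchange at this position depends on what the nitrogen carries.

The compounds shown leave open whether a methoxy group or a longer chain such as propoxy would behave like ethoxy at this position. They also cannot tell whether a plain acetyl group on the nitrogen would show the same dependence.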